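Solubility series: variation at the saturated chain carbon

The compounds below may be only part of what the source reports. "The series", "measured", "known", "first", "only" and "open" are said of these compounds alone.

Compound 3 `CC(C)C(c1nnc[nH]1)c1ccc(-c2ccc3cccc(F)c3c2)[nH]c1=O` gives 24500 nM in a physicochemical assay for solubility, in phosphate buffer, measured as kinetic solubility; a higher number here means a more soluble compound, a lower number a less soluble compound. It sits within the usual scatter of both earlier compounds: compound 1 `CC(C)C(Cc1ncc[nH]1)c1ccc(-c2ccc3cccc(F)c3c2)[nH]c1=O` gives 22100 nM, and compound 2 `CC(C)C(c1ccc(-c2ccc3cccc(F)c3c2)[nH]c1=O)N1CCCCC1=O` gives 23100 nM. The steps of a 1.1-fold higher number from compound 1 to compound 3 (0.04 log units; within the scatter) and a 1.1-fold higher number from compound 2 to compound 3 (0.03 log units; within the scatter) are both within the scatter, as is a 1.0-fold higher number from compound 1 to compound 2 (0.02 log units; within the scatter), so the three measured compounds cannot be set apart from one another in this assay.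

Compound 4 `CC(C)C(Cc1nnn[nH]1)c1ccc(-c2ccc3cccc(F)c3c2)[nH]c1=O` differs from compound 3 by (1H-tetrazol-5-yl)methyl in place of 4H-1,2,4-triazol-3-yl on a saturated chain carbon bound to an aromatic carbon and a saturated chain carbon. Among the compounds with values here, no measured step covers this exact exchange. Within the data shown here, the steps that bear on it are the three exchanges at the same saturated chain carbon, each of which left this assay unchanged beyond the scatter. On that basis the exchange to the (1H-tetrazol-5-yl)methyl group is expected to give no step beyond the scatter either, with a 1.0-fold lower number from compound 3 to compound 4 (0.01 log units; within the scatter) as the expected step. Compound 4 is therefore estimated at 24000 nM in this assay, with a range from 12000 nM to 48000 nM.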

Compound 4, solubility: 27300 nM
The estimate for compound 4 lay 1.1-fold (0.06 log units) below the measured number, within the range that was stated.
By their numbers in this assay, from the lowest: compounds 1, 2, 3 and 4 (each within the scatter of the next).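

At the saturated chain carbon bound to an aromatic carbon and a saturated chain carbon, a ring with 4 hetero atoms now joins the exchanges that leave this assay inside the scatter: (1H-tetrazol-5-yl)methyl in place of 4H-1,2,4-triazol-3-yl gives a 1.1-fold higher number from compound 3 to compound 4 (0.05 log units; within the scatter), and in place of 2-oxopiperidin-1-yl it gives a 1.2-fold higher number from compound 2 to compound 4 (0.07 log units; within the scatter). Within the data shown here, the first exchange that keeps the chain and changes only the ring, 1H-tetrazol-5-yl in place of 1H-imidazol-2-yl, gives a 1.2-fold higher number from compound 1 to compound 4 (0.09 log units; within the scatter), so that ring change alone also stays within the scatter. Nothing at hand accounts for these numbers staying together.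

Still open, going by these compounds, is whether any group at this carbon moves the number beyond the scatter, for instance a primary amine, a carboxylic acid or a longer chain carrying the tetrazole ring. Also open, on these data alone, is whether the same picture holds on a core other than the shared one.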